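Thiosemicarbazone aryl variation on a terpene-derived core

The source may report more compounds than this note shows. Statements on the series, on what has been measured and on what is new or still open speak of the compounds shown alone.

Measured compounds:
compound 1 `CC1=CC[C@@H]([C@@](C)(O)CCCC(C)(C)NC(=S)N/N=C\c2ccc(C)cc2)CC1` — 140 nM
compound 2 `CC1=CC[C@@H]([C@@](C)(O)CCCC(C)(C)NC(=S)N/N=C\c2ccc(N(C)C)cc2)CC1` — 80 nM

In a functional assay on K562 cells (Homo sapiens) for cytotoxicity, read by sulforhodamine B assay (on this read-out lower numbers stand for stronger inhibition of growth and higher numbers for weaker inhibition of growth), compound 2 gives 80 nM, the lowest of the two numbers; its nearest neighbour is compound 1, and the step of a 1.8-fold lower number from compound 1 to compound 2 (0.24 log units; within the scatter) lies within the scatter. Compound 3 `CC1=CC[C@@H]([C@@](C)(O)CCCC(C)(C)NC(=S)N/N=C\c2ccccc2[N+](=O)[O-])CC1` carries 2-nitrophenyl in place of 4-(dimethylamino)phenyl on a carbon with a double bond to nitrogen. Among the measured compounds shown here, no measured step touches this exchange; the only step known, a 1.8-fold lower number from compound 1 to compound 2 (0.24 log units; within the scatter), is small, so the series gives no hint of a large effect of varying the aryl group. Compound 3 is therefore expected near compound 2 in this assay, with a 1.5-fold higher number from compound 2 to compound 3 (0.18 log units; within the scatter) and an estimate of 120 nM ranging from 40 nM to 400 nM.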

Compound 3, concentration for 50% growth inhibition: 190 nM
Beside the measured number, compound 3's estimate is 1.6-fold (0.20 log units) below it; measured number inside the range.
By their numbers in this assay, from the lowest: compounds 2, 1 and 3 (each within the scatter of the next, the first and the last beyond it).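

In this assay, among the compounds shown here, the exchange of 4-(dimethylamino)phenyl for 2-nitrophenyl on a carbon with a double bond to nitrogen is the only step at this position beyond the scatter, a modest one: a 2.4-fold higher number from compound 2 to compound 3 (0.38 log units; beyond the scatter). The exchange of 4-methylphenyl for 2-nitrophenyl stays within the scatter, with a 1.4-fold higher number from compound 1 to compound 3 (0.13 log units; within the scatter), so the aryl variation shown here spans only a narrow range. No evidence available here accounts for the step from compound 2 to compound 3. The compounds shown leave open how a 4-nitrophenyl or a pyridyl group would read at this position.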